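The source may report more compounds than this note shows. Statements on the series, on what has been measured and on what is new or still open speak of the compounds shown alone.

Measured so far:
compound 1 `C=C1CC[C@@H]2[C@](C)(CNCc3ccccc3)[C@H](O)CC[C@@]2(C)[C@@H]1/C=C/C1=CCOC1=O` — 960 nM
compound 2 `C=C1CC[C@@H]2[C@](C)(CNCc3ccc(OC)c(OC)c3)[C@H](O)CC[C@@]2(C)[C@@H]1/C=C/C1=CCOC1=O` — 3740 nM
compound 3 `C=C1CC[C@@H]2[C@](C)(CNCc3ccc(C#N)cc3)[C@H](O)CC[C@@]2(C)[C@@H]1/C=C/C1=CCOC1=O` — 1130 nM

In a functional assay on BMMC cells (Mus musculus, strain C57BL/6) for inhibition, with stated times of 5 days and 48 h (on this read-out lower numbers stand for stronger inhibition and higher numbers for weaker inhibition), compound 3 stands second highest of the three numbers, with compound 1 nearest and compound 2 furthest. Compound 4 `C=C1CC[C@@H]2[C@](C)(CNCc3cccs3)[C@H](O)CC[C@@]2(C)[C@@H]1/C=C/C1=CCOC1=O` is not yet measured; it differs from compound 3 by thiophen-2-yl in place of 4-cyanophenyl on a saturated chain carbon bound to an amine nitrogen. Among the compounds with values here, two steps bear on the aryl group at this position: a 1.2-fold higher number from compound 1 to compound 3 (0.07 log units; within the scatter), and a 3.9-fold higher number from compound 1 to compound 2 (0.59 log units; beyond the scatter), the latter seen again the other way in a 3.3-fold lower number from compound 2 to compound 3 (0.52 log units; beyond the scatter). Cyano in place of hydrogen left the number essentially unmoved; only 3,4-dimethoxyphenyl gave a step beyond the scatter. Exchanging the six-membered aromatic ring for a five-membered one is therefore expected to give a step within the scatter, a 1.1-fold higher number from compound 3 to compound 4 (0.03 log units; within the scatter), with at most a slight lean to a higher number. The estimate for compound 4 is 1200 nM, within a range of 450 nM to 3200 nM.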

Compound 4, half-maximal inhibitory concentration: 1070 nM
Beside the measured number, compound 4's estimate is 1.1-fold (0.05 log units) above it, and the stated range covers the measured number.
By their numbers in this assay, from the lowest: compounds 1, 4 and 3 (each within the scatter of the next); then compound 2.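

In this assay, a five-membered aromatic ring with a sulfur atom at this place on a saturated chain carbon bound to an amine nitrogen gives a 1.1-fold lower number from compound 3 to compound 4 (0.02 log units; within the scatter) and a 1.1-fold higher number from compound 1 to compound 4 (0.05 log units; within the scatter), so phenyl, 4-cyanophenyl and thiophen-2-yl are not separated. Compound 2 alone stands apart, with a 3.5-fold lower number from compound 2 to compound 4 (0.54 log units; beyond the scatter) in this series. Nothing available explains this pattern.

Still open, as far as these compounds go, is whether a saturated cyclohexyl group or a carboxylic acid in place of the aromatic ring would stay at this level. Also open, from the compounds shown here alone, is whether one methoxy group alone would give the step seen with 3,4-dimethoxyphenyl.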